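This account rests on a few compounds, and the source may have more. Where it says the series, first, only, none or still open, it means among the compounds named here.

Three compounds have been measured in a functional assay on DU-145 cells (Homo sapiens) for inhibition, read by trypan blue exclusion, with a stated time of 96 h; on this read-out lower numbers stand for stronger inhibition of growth and higher numbers for weaker inhibition of growth:

- compound 1 `Cc1ccc(S(=O)(=O)/C(=C/c2sccc2C)C(=O)c2ccc(Cl)cc2)cc1`: 10000 nM
- compound 2 `COc1ccccc1/C=C(\C(=O)c1ccc(Cl)cc1)S(=O)(=O)c1ccc(C)cc1`: 1000 nM
- compound 3 `COc1ccc(/C=C(\C(=O)c2ccc(Cl)cc2)S(=O)(=O)c2ccc(C)cc2)cc1O`: 1000 nM

Compound 3 shares the lowest of these numbers with compound 2, shown by no change at the digits printed from compound 2 to compound 3 (within the scatter). The next candidate is compound 4 `Cc1ccc(S(=O)(=O)/C(=C/c2cccs2)C(=O)c2ccc(Cl)cc2)cc1`, which has thiophen-2-yl in place of 3-hydroxy-4-methoxyphenyl on a double-bonded chain carbon bound to a double-bonded chain carbon.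

The most relevant measured step is a 10-fold lower number from compound 1 to compound 3 (1.00 log units; beyond the scatter), as compound 1 carries 3-methylthiophen-2-yl at that place. The step of a 10-fold lower number from compound 1 to compound 2 (1.00 log units; beyond the scatter) is of the same size. Both steps replace a thiophene with a substituted phenyl, whereas the new change runs the opposite way, so a higher number is expected in this assay. No measurement shows how thiophen-2-yl itself behaves, so the size remains uncertain and may fall short of those steps. The expected change is a 5.0-fold higher number from compound 3 to compound 4 (0.70 log units; beyond the scatter). For compound 4 the estimated value is 5000 nM, with an expected range from 1500 nM to 15000 nM.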

Compound 4, concentration for 50% growth inhibition: 25000 nM
The estimate for compound 4 lay 5.0-fold (0.70 log units) below the measured number; measured number outside the range, above it.
By their numbers in this assay, from the lowest: compounds 2 and 3 (each within the scatter of the next); then compound 1; then compound 4.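

Thiophen-2-yl on a double-bonded chain carbon bound to a double-bonded chain carbon gives a far higher number in this assay than the earlier compounds had shown for any group there, with a 25-fold higher number from compound 3 to compound 4 (1.40 log units; beyond the scatter) and a 25-fold higher number from compound 2 to compound 4 (1.40 log units; beyond the scatter) when it replaces the two substituted phenyl groups. The two thiophene compounds also give a comparison that was not available before, with a 2.5-fold higher number from compound 1 to compound 4 (0.40 log units; beyond the scatter) for hydrogen in place of methyl on an aromatic carbon, so the methyl-bearing thiophene gives the lower number of the pair. No evidence is available to explain either change.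

The compounds shown do not separate the contribution of the six-membered aromatic ring from that of its hydroxy and methoxy groups. From the compounds shown here alone, how an unsubstituted phenyl or a pyridine ring would behave at this place remains open, as does the effect of a methoxy group on the thiophene.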